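The source may hold more compounds than are shown below. What is called first, only, known or untested is meant among the compounds shown, and "the series" means these compounds.

Measured compounds:
compound 1, `CCC(C)(C)Cc1c[nH]c(CCc2ccc(-c3cnccn3)cc2)n1`, 431 nM
compound 2, `CCC(C)(C)Cc1c[nH]c(CCc2ccc(-c3cccc(C#N)n3)cc2)n1`, 193 nM
compound 3, `CCC(C)(C)Cc1c[nH]c(CCc2ccc(-c3cccnc3)cc2)n1`, 131 nM

In a functional assay on HEK293 cells for agonist activity at Bombesin receptor subtype-3 (Homo sapiens), read by luminescence and calcium flux, with a stated time of 10 min (a lower number here means that less compound is needed, a higher number that more compound is needed for the effect), compound 1 stands highest of the three numbers. Its nearest neighbour is compound 2, reached by a 2.2-fold lower number from compound 1 to compound 2 (0.35 log units; beyond the scatter), and the furthest is compound 3, reached by a 3.3-fold lower number from compound 1 to compound 3 (0.52 log units; beyond the scatter). Compound 4, `CCC(C)(C)Cc1c[nH]c(CCc2ccc(-c3cccnc3C(=O)O)cc2)n1`, arises from compound 1 by 2-carboxypyridin-3-yl in place of pyrazin-2-yl on an aromatic carbon. The two steps from compound 1 bear on this change: both replace the pyrazin-2-yl with another six-membered aromatic ring and both give modestly lower numbers. Among the compounds with values here, the carboxylic acid of compound 4, however, has no counterpart among the measured compounds, so the expectation is less secure. The step to compound 4 is therefore expected to be modest and downward, as a 1.7-fold lower number from compound 1 to compound 4 (0.22 log units; within the scatter). Compound 4 is estimated at 260 nM, within 80 nM to 900 nM.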

Compound 4, half-maximal effective concentration: 1260 nM
The estimate for compound 4 lay 4.8-fold (0.69 log units) below the measured number; the measured number lies above the stated range.
By their numbers in this assay, from the lowest: compounds 3 and 2 (each within the scatter of the next); then compound 1; then compound 4.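

In this assay, within the data shown here, 2-carboxypyridin-3-yl is the first replacement for pyrazin-2-yl at this position that raises the number (a 2.9-fold higher number from compound 1 to compound 4 (0.47 log units; beyond the scatter)), whereas the earlier replacements lowered it. The sharpest reading is carboxy in place of hydrogen on an aromatic carbon (a 9.6-fold higher number from compound 3 to compound 4 (0.98 log units; beyond the scatter)), and the number also rises against the nitrile-bearing ring (a 6.5-fold higher number from compound 2 to compound 4 (0.81 log units; beyond the scatter)). Nothing available gives a cause for this rise. On these data alone, whether a methyl ester or a primary amide in place of the carboxylic acid would also raise the number remains open.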